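The source may report more compounds than this note shows. Statements on the series, on what has been measured and on what is new or still open speak of the compounds shown alone.

The measured compounds:

Compound 1, `CC(O)(CSc1cccc(S(F)(F)(F)(F)F)c1)C(=O)Nc1ccc(C#N)cc1C(F)(F)F`, in a functional assay on CWR22R cells (Homo sapiens) for antiproliferative activity, read by propidium iodide staining, with a stated time of 96 h (a lower number here means a stronger inhibitor, a higher number a weaker inhibitor), gives 21600 nM.
Compound 2, `CC(O)(CSc1cccc(S(F)(F)(F)(F)F)c1)C(=O)Nc1ccc([N+](=O)[O-])cc1C(F)(F)F`, in this assay gives 17500 nM.
Compound 3, `CC(O)(CS(=O)(=O)c1ccc(S(F)(F)(F)(F)F)cc1)C(=O)Nc1ccc(C#N)cc1C(F)(F)F`, in this assay gives 19400 nM.

All three compounds share the same amide-linked aryl fragment bearing a trifluoromethyl group, and they differ in how the other half is built and in the group that sits on that aryl ring. Compound 1 and compound 2 have the same core and differ in one place: nitro in place of cyano on an aromatic carbon. This change gave a 1.2-fold lower number from compound 1 to compound 2 (0.09 log units; within the scatter), so on this core the two compounds are indistinguishable within the usual scatter. Compound 3 carries a different core; the difference between the core of compound 1 and the core of compound 3 is not broken down here. The values of compound 1 and compound 3 in this assay lie within the scatter of each other, as do those of compound 2 and compound 3.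

Compound 4, `CC(O)(CS(=O)(=O)c1ccc(S(F)(F)(F)(F)F)cc1)C(=O)Nc1ccc([N+](=O)[O-])cc1C(F)(F)F`, has not yet been measured. It stands to compound 3 as compound 2 stands to compound 1: nitro in place of cyano on an aromatic carbon. The place of the change is described in the same words for both pairs, so this is the same change made on a second core. Because the earlier pair showed a 1.2-fold lower number from compound 1 to compound 2 (0.09 log units; within the scatter), the step from compound 3 to compound 4 is expected to be of similar small size, a 1.2-fold lower number from compound 3 to compound 4 (0.07 log units; within the scatter), and to stay within the scatter. For compound 4 in this assay the estimate is 16500 nM, with a likely range from 8000 nM to 34000 nM.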

Compound 4, half-maximal inhibitory concentration: 18700 nM
Compound 4: the middle estimate sits 1.1-fold (0.05 log units) below what was measured; the measured number falls inside the stated range.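

In this assay, nitro in place of cyano on an aromatic carbon, now made on the core of compound 3, gave a 1.0-fold lower number from compound 3 to compound 4 (0.02 log units; within the scatter), so on this second core too the two compounds cannot be told apart. Set beside the earlier pair, the change looks the same on both cores, with no difference between the two steps that rises out of the noise: the same change on two cores in this assay, a 1.2-fold lower number (0.09 log units; within the scatter) from compound 1 to compound 2 and a 1.0-fold lower number (0.02 log units; within the scatter) from compound 3 to compound 4, 1.2-fold (0.08 log units) apart, within the scatter of two such steps This shows that, on these two cores, exchanging cyano for nitro leaves the number in this assay effectively where it was, but it is an agreement between two steps that are both within the scatter, not the transfer of a clear effect from one core to another, and it does not show that the change would stay this small on any further core.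

The compounds shown carry only cyano or nitro at this place, which leaves open whether an amine, a carboxylic acid or a plain hydrogen there would shift the number in this assay. Also open, on these data alone, is whether the change would remain as small if the sulfur-linked aryl half gave way to a longer chain or a simple alkyl group.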